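The source may report more compounds than this note shows. Statements on the series, on what has been measured and on what is new or still open speak of the compounds shown alone.

Compound 3 is `N#CC1=C(N)OC(c2c[nH]c3ccccc23)=C(C#N)C1c1ccc(F)cc1`. In a functional assay, tested at 50 ug/mL (on this read-out lower numbers stand for a weaker effect and higher numbers for a stronger effect at the one concentration tested), compound 3 gives 8.4%. Its closest neighbour among the measured compounds is compound 2, which is `CN(C)c1ccc(C2C(C#N)=C(N)OC(c3c[nH]c4ccccc34)=C2C#N)cc1`; in this assay compound 2 gives 14.4%, and the two numbers lie within the scatter of each other, as the step of a number 6 percentage points lower from compound 2 to compound 3 (within the scatter) shows. Compound 1, which is `N#CC1=C(N)OC(c2c[nH]c3ccccc23)=C(C#N)C1c1ccc2ccccc2c1`, is reported in this assay as "not active" (no number reported), so no number stands for it.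

Compound 4 is `N#CC1=C(N)OC(c2c[nH]c3ccccc23)=C(C#N)C1c1cccc2ccccc12`. It differs from compound 3 in one place: naphthalen-1-yl in place of 4-fluorophenyl on a saturated ring carbon. Going by the values given here, only one measured step touches the same part of the shared core, the exchange a number 6 percentage points lower from compound 2 to compound 3 (within the scatter) on the aromatic ring, and that step stayed within the scatter. Among the compounds with values here, no measured step exchanges a 4-fluorophenyl for a naphthalen-1-yl, and compound 1, the only other compound that carries a two-ring aromatic group at that position, has no number in this assay at all. On this basis the step of a number 1.4 percentage points lower from compound 3 to compound 4 (within the scatter) is expected to be small, if anything downward, and to stay within the scatter. Compound 4 is therefore estimated to give 7% in this assay, expected to lie between 0% and 20%.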

Compound 4, a percentage reported as activity, at one concentration (the size of the read-out at that concentration, not a potency): 4.7%
The estimate for compound 4 lay 2.3 percentage points above the measured number; measured number inside the range.
By their numbers in this assay, from the lowest: compounds 4, 3 and 2 (each within the scatter of the next).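

In this assay, the exchange at the saturated ring carbon now has a measured step for a two-ring aromatic group: replacing 4-fluorophenyl with naphthalen-1-yl gives a number 3.7 percentage points lower from compound 3 to compound 4 (within the scatter), and replacing 4-(dimethylamino)phenyl with the same group gives a number 9.7 percentage points lower from compound 2 to compound 4 (within the scatter). Going by these compounds alone, until now, the only compound with a two-ring aromatic group at this position had no number, so the effect of adding a second six-membered aromatic ring of carbon only could not be read; in these two steps, that change does not move the number beyond the scatter. The data offer no measurement that would account for this result.

The compounds shown leave open how a cyclohexyl group or a pyridine ring at this position, or a carboxylic acid on the phenyl ring, would read in this assay, and whether any group here can move the number beyond the scatter. They also leave open how compound 1, reported as "not active" (no number reported), relates to the three compounds with numbers, and what exchanges at the 1H-indol-3-yl group or the amino group would do.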